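From Difluorophenyl to Propylphenyl on the Amide Carbonyl

The source may hold more compounds than are shown below. What is called first, only, known or untested is meant among the compounds shown, and "the series" means these compounds.

Compound 1 `O=C(Nc1cccc(-c2oc3cc(-c4ccc(F)cc4)ccc3c(=O)c2O)c1)c1ccc(F)cc1F` gives 11200 nM in a functional assay on MDA-MB-231 cells (Homo sapiens) for antiproliferative activity, read by CCK-8 assay, with a stated time of 72 h (a lower number here means a stronger inhibitor, a higher number a weaker inhibitor), the highest of the two numbers recorded there. Its nearest neighbour, compound 2 `O=C(Nc1cccc(-c2oc3cc(-c4ccc(F)cc4)ccc3c(=O)c2O)c1)c1ccc(Cl)nc1`, gives 1760 nM in this assay; the change between them, 6-chloropyridin-3-yl in place of 2,4-difluorophenyl on a carbonyl carbon, brought a 6.4-fold lower number from compound 1 to compound 2 (0.80 log units; beyond the scatter). Compound 3 `CCCc1ccc(C(=O)Nc2cccc(-c3oc4cc(-c5ccc(F)cc5)ccc4c(=O)c3O)c2)cc1` is related to compound 1 by 4-propylphenyl in place of 2,4-difluorophenyl on a carbonyl carbon. Among the measured compounds shown here, the single measured step concerns a different group entering at the same carbonyl carbon, so it bears on compound 3 only by showing that a replacement there has once given a clearly lower number. With one precedent of another kind, the expectation for compound 3 is loosely held. For compound 3 in this assay the expected step is a 2.2-fold lower number from compound 1 to compound 3 (0.35 log units; beyond the scatter), leaning towards a lower number yet possibly within the scatter. The estimated value of compound 3 is 5000 nM, with a range from 1500 nM to 16000 nM.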

Compound 3, half-maximal inhibitory concentration: 32200 nM
The estimate for compound 3 lay 6.4-fold (0.81 log units) below the measured number; the measured number lies above the stated range.
By their numbers in this assay, from the lowest: compound 2; then compound 1; then compound 3.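

Among the compounds shown here, the replacement on this carbonyl carbon does not always lower the number in this assay: 4-propylphenyl in place of 2,4-difluorophenyl gave a 2.9-fold higher number from compound 1 to compound 3 (0.46 log units; beyond the scatter) and so ran opposite to the one earlier step. The position therefore moves the number in both directions, and the two groups that entered lie far apart, with an 18-fold higher number from compound 2 to compound 3 (1.26 log units; beyond the scatter) as the largest step among the three compounds. Nothing given here explains these differences.

This step takes away both fluorines and brings in the propyl chain at once, so the compounds shown cannot tell which part goes with the higher number, and a plain phenyl on the carbonyl carbon would separate the two. Also open, as far as these compounds go, is how an amine or a carboxylic acid on that ring would read, since only carbon-ring and chloropyridine groups appear here.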